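This account rests on a few compounds, and the source may have more. Where it says the series, first, only, none or still open, it means among the compounds named here.

Of the compounds shown here, two with the same core have been tested in a functional assay, with a stated time of 150 min, tested at 35 ug/mL; on this read-out higher numbers stand for a stronger effect at the one concentration tested and lower numbers for a weaker effect. Compound 1 `COc1ccc(C(=O)c2sc(Nc3ccccc3)c(C(=O)O)c2C)cc1` carries a plain phenyl on the amine and gives 61.2%. Compound 2 `COc1ccc(C(=O)c2sc(Nc3ccc(C)cc3)c(C(=O)O)c2C)cc1` carries a 4-methylphenyl there instead, and in this assay compound 2 is reported only as "not active" (no number reported), with no number behind it. So on the figures shown, compound 2 stands with no single value of its own, only the word that no effect was seen at the one concentration tested.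

Compound 3 `COc1ccc(Nc2sc(C(=O)c3ccc(OC)cc3)c(C)c2C(=O)O)cc1` is the next compound. It differs from compound 2 in one place: methoxy in place of methyl on an aromatic carbon. For the measured compounds named here, no measured pair in this set separates a methyl from a methoxy, so there is no measured step to lean on. The expectation is that the step from compound 2 to compound 3 in this assay is small, either none beyond the scatter or a modest rise, since compound 3 keeps the same substituted phenyl pattern that left compound 2 inactive. Compound 3 is therefore expected to give about 15%, within a range from 0% to 45%.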

Compound 3, a percentage reported as activity, at one concentration (the size of the read-out at that concentration, not a potency): 51%
The estimate for compound 3 lay 36 percentage points below the measured number; the measured number lies above the stated range.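

In this assay, a group at this place on the phenyl ring does not by itself end the effect: with 4-methoxyphenyl on the amine, the read-out shows a number 10.2 percentage points lower from compound 1 to compound 3 (beyond the scatter). Swapping methyl for methoxy at the same spot separates compound 2, reported only as not active, from compound 3, which keeps most of the effect of compound 1, so the outcome here depends on which group is present and not simply on whether the place is filled. The step between compound 2 and compound 3 cannot be read as a number, and nothing available explains why these two closely related groups part so sharply.

With only hydrogen, methyl and methoxy at this place, two substituted compounds cannot show a trend, and each result rests on a single reading at one concentration. On these data alone, it remains open whether an ethoxy group, a hydroxyl group, an amine or a chlorine atom at the same spot would behave like the methoxy of compound 3 or the methyl of compound 2.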